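A few compounds are considered here, and "the series" means these few. Any claim that something is new, unique, unknown or untested is made for them only; others in the source may bear on it.

Measured compounds:
compound 1, `CC(C)(C)OC(=O)NCCCCNCCCN(Cc1cccc(-c2ccccc2)c1)Cc1cccc(-c2ccccc2)c1`: > 100000 nM
compound 2, `CC(C)(C)OC(=O)NCCCCNCCCN(Cc1ccc(-c2ccccc2)cc1)Cc1ccc(-c2ccccc2)cc1`: > 100000 nM
compound 3, `CC(C)(C)OC(=O)NCCCCNCCCN(Cc1ccc2ccccc2c1)Cc1ccc2ccccc2c1`: 4300 nM

In an ADME assay on RAW264.7 cells (Mus musculus) for cytotoxicity, read by resazurin assay, with a stated time of 48 h (a lower number here means that less compound is tolerated, a higher number that more compound is tolerated), compound 1 gives > 100000 nM, which is a limit of the assay and not a number. Compound 2 likewise sits at a limit, > 100000 nM. Going by the values given here, compound 3 is the one compound with a number, giving 4300 nM in this assay. So compound 1 stands at the upper edge of what was measured, together with compound 2, as described by the limit of > 100000 nM in this assay, at which 2 of the 3 values shown sit; compound 3 is the only compound with a number in this assay.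

Compound 4, `NCCCCNCCCN(Cc1cccc(-c2ccccc2)c1)Cc1cccc(-c2ccccc2)c1`, has not yet been measured. It differs from compound 1 in one place: hydrogen in place of tert-butoxycarbonyl on an amine nitrogen. Among the compounds with values here, no pair of measured compounds shows this change, so there is no measured step to lean on. The expectation is that compound 4 is tolerated less than compound 1, by a step beyond the usual scatter, estimated as an at least 3.3-fold lower number from compound 1 to compound 4 (0.52 log units; beyond the scatter). For compound 4 the estimated value in this assay is 30000 nM, expected to fall between 6000 nM and 100000 nM.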

Compound 4, half-maximal cytotoxic concentration: 30300 nM
Estimate against measurement, compound 4: 1.0-fold (0.00 log units) below, within the range that was stated.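

In this assay the amine nitrogen at the chain end now has a measured step: hydrogen in place of tert-butoxycarbonyl gives an at least 3.3-fold lower number from compound 1 to compound 4 (0.51 log units; beyond the scatter) in this one pair. Compound 1 sits at a limit, so this step has no fixed size and could be larger than its printed figure: the limit of > 100000 nM in this assay, at which 2 of the 4 values shown sit. Going by these compounds alone, the result is the first sign that (tert-butoxycarbonyl)amino and amino at this position are not equal in this read-out, though it rests on the core of compound 1 alone, and it gives no cause for the difference.

On these data alone, whether the same change has a similar effect on the cores of compound 2 and compound 3 remains open. As far as these compounds go, it is also open what an acetyl or a methyl group on this nitrogen would give in place of hydrogen.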